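This account rests on a few compounds, and the source may have more. Where it says the series, first, only, none or still open, it means among the compounds named here.

Measured so far:
Compound 1, `COc1ccc(OC)c(/C=N/NC(=O)Nc2ccc(Oc3ccnc(-c4nncn4CCN(C)C)c3)c(F)c2)c1`, in a functional assay on NCI-H460 cells (Homo sapiens) for cytotoxicity, read by MTT assay, with a stated time of 72 h (on this read-out higher numbers stand for weaker inhibition and lower numbers for stronger inhibition), compound 1 gives 2930 nM.
Compound 2, `COc1cc(/C=N/NC(=O)Nc2ccc(Oc3ccnc(-c4nncn4CCN(C)C)c3)c(F)c2)cc(OC)c1OC`, in this assay compound 2 gives 2770 nM.
Compound 3, `COc1ccc(/C=N/NC(=O)Nc2ccc(Oc3ccnc(-c4nncn4CCN(C)C)c3)c(F)c2)cc1O`, in this assay compound 3 gives 620 nM.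

All three share the same core and differ only in the aryl group on the carbon double-bonded to nitrogen. Compound 3, which carries the 3-hydroxy-4-methoxyphenyl there, has the lowest number of the three in this assay, and both of its neighbours lie beyond the scatter: a 4.7-fold lower number from compound 1 to compound 3 (0.67 log units; beyond the scatter) and a 4.5-fold lower number from compound 2 to compound 3 (0.65 log units; beyond the scatter). Between the two all-methoxy aryls themselves the gap is small, a 1.1-fold lower number from compound 1 to compound 2 (0.02 log units; within the scatter).

Compound 4, `CN(C)CCn1cnnc1-c1cc(Oc2ccc(NC(=O)N/N=C/c3ccc(O)cc3O)cc2F)ccn1`, is to be measured in this assay. The change from compound 3 is 2,4-dihydroxyphenyl in place of 3-hydroxy-4-methoxyphenyl on a carbon with a double bond to nitrogen. Among the measured compounds shown here, the measured steps bear on it only indirectly: they show that the one aryl bearing a hydroxy group gave a modestly lower number than either aryl bearing only methoxy groups, but no step exchanges one hydroxy-bearing aryl for another, nor removes the methoxy group entirely. The nearest guide is therefore compound 3 itself, and a step of no more than modest size in either direction is expected, most likely within the scatter: a 1.2-fold higher number from compound 3 to compound 4 (0.08 log units; within the scatter). On that basis compound 4 is estimated at 750 nM in this assay, with a range from 250 nM to 2300 nM.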

Compound 4, half-maximal inhibitory concentration: 11300 nM
For compound 4 the middle estimate is 15-fold (1.18 log units) below the measured one, outside the stated range (above it).
By their numbers in this assay, from the lowest: compound 3; then compounds 2 and 1 (each within the scatter of the next); then compound 4.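

The step of an 18-fold higher number from compound 3 to compound 4 (1.26 log units; beyond the scatter) shows that this position separates two aryl groups that both carry hydroxy groups: 2,4-dihydroxyphenyl has one heavy atom fewer than 3-hydroxy-4-methoxyphenyl and one more hydrogen-bond donor, yet the number in this assay changes by a large amount. Compound 4 also has a higher number than the aryls bearing only methoxy groups, with a 4.1-fold higher number from compound 2 to compound 4 (0.61 log units; beyond the scatter) and a 3.9-fold higher number from compound 1 to compound 4 (0.59 log units; beyond the scatter), so the lower number of compound 3 cannot be read as a general benefit of having a hydroxy group on this ring, and compound 4 is the exception to that reading. Nothing available here accounts for the difference between these two aryl groups.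

The two rings differ in both the methoxy group and the arrangement of the hydroxy groups, so the compounds shown cannot separate these two changes. Going by these compounds, it also remains open how this position would respond to an amine or a fluorine in place of the hydroxy group of 3-hydroxy-4-methoxyphenyl, or to a longer chain in place of its methoxy group.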